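Notes on compound 3: 2-ethoxyethoxy addition and cytotoxicity

A few compounds are considered here, and "the series" means these few. Any claim that something is new, unique, unknown or untested is made for them only; others in the source may bear on it.

Within the data shown here, compound 1 `O=S(=O)(c1ccc(-c2ccc3ncnc(Nc4ccc(OCc5cccc(F)c5)cc4)c3c2)cc1)N1CCOCC1` and compound 2 `O=S(=O)(c1ccc(-c2ccc3ncccc3c2)cc1)N1CCOCC1` are the two measured members. In a toxicity assay on HepG2 cells (Homo sapiens) for cytotoxicity, read by MTT assay, with a stated time of 48 h (on this read-out higher numbers stand for lower toxicity in this test and lower numbers for higher toxicity in this test), compound 1 reaches only the assay limit > 20 uM. Compound 2 likewise stops at the assay limit > 20 uM in this assay. Compound 2 thus sits where every measured value sits: the limit of > 20 uM in this assay, at which 2 of the 2 values shown sit. Compound 3 `CCOCCOc1ccnc2ccc(-c3ccc(S(=O)(=O)N4CCOCC4)cc3)cc12` carries 2-ethoxyethoxy in place of hydrogen on an aromatic carbon. Among the measured compounds shown here, no step between measured compounds is available, so no size can be read from the data; the step that the limit leaves unreadable from compound 2 to compound 3 is expected to be none beyond the scatter. Compound 3 is estimated at 30 uM, within 15 uM to 80 uM, and most likely reported again only as a limit.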

Compound 3, half-maximal toxic concentration: > 20 uM
Compound 3 ended at the assay's limit; the forecaster's own chance of this, stated with the estimate: 75%; the middle value does not contradict the limit.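

No step can be read between compound 2 and compound 3: both values are assay limits. The compounds shown leave open whether 2-ethoxyethoxy in place of hydrogen on an aromatic carbon alters toxicity in this test at all: the limit of > 20 uM in this assay, at which 3 of the 3 values shown sit.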